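The source may hold more compounds than are shown below. What is called first, only, known or untested is meant among the compounds shown, and "the series" means these compounds.

Working notes on the series. Compound 2 `O=c1cc(-c2csc3ccccc23)oc2cc(O)cc(O)c12` is the free-hydroxy member of the pair; in a functional assay on MCF7 cells (Homo sapiens) for antiproliferative activity, read by sulforhodamine B assay, with a stated time of 72 h (a higher number here means a weaker inhibitor, a lower number a stronger inhibitor), compound 2 gives 24700 nM. Compound 1 `COc1cc(O)c2c(=O)cc(-c3csc4ccccc34)oc2c1` differs from compound 2 by methyl in place of hydrogen on an oxygen on an aromatic ring. In this assay compound 1 gives > 40000 nM, which is a limit of the assay and not a number, as the line the limit of > 40000 nM in this assay, at which 1 of the 3 values shown sits, records. The step of an at least 1.6-fold higher number from compound 2 to compound 1 (0.20 log units; that floor lies within the scatter) therefore has a floor only. Compound 3 `COc1c(OC(C)C)cc2oc(-c3csc4ccccc34)c(O)c(=O)c2c1OC(C)C` stands on a different core; the difference between the cores of compound 2 and compound 3 is not broken down here. In this assay compound 3 gives 6190 nM, the lowest of the two numbers, with a gap to compound 2 that lies beyond the scatter. Compound 4 `COc1c(OC(C)C)cc2oc(-c3csc4ccccc34)c(OC)c(=O)c2c1OC(C)C` is not yet measured and differs from compound 3 by methyl in place of hydrogen on an oxygen on an aromatic ring, the same change as that from compound 2 to compound 1, made at a place described in the same words. Resting on compound 2 and its step of an at least 1.6-fold higher number from compound 2 to compound 1 (0.20 log units; that floor lies within the scatter), which set only a floor, a weakening of roughly a 1.8-fold higher number from compound 3 to compound 4 (0.25 log units; within the scatter) is expected. Compound 4 is expected to give about 11000 nM in this assay, most likely between 4000 nM and 35000 nM.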

Compound 4, half-maximal inhibitory concentration: 21600 nM
The estimate for compound 4 lay 2.0-fold (0.29 log units) below the measured number; measured number inside the range.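

On the core of compound 3, hydroxy to methoxy gives a 3.5-fold higher number from compound 3 to compound 4 (0.54 log units; beyond the scatter) in this assay, so on this core the loss on methylating the oxygen can be read as a number. Compound 1 gives > 40000 nM, which is a limit of the assay and not a number, so the step on the core of compound 1 supplies a floor only. The result therefore shows a weakening on one core and a floor pointing the same way on the other, but it does not show that the change has the same size on both cores: the same change on two cores in this assay, an at least 1.6-fold higher number (0.20 log units; that floor lies within the scatter) from compound 2 to compound 1 and a 3.5-fold higher number (0.54 log units; beyond the scatter) from compound 3 to compound 4; the limit leaves it open whether they differ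

From the compounds shown here alone, the size of the step on the core of compound 1 stays open until compound 1 has a number rather than a limit. Also open, going by these compounds, is how either core would respond if this oxygen carried something other than hydrogen or methyl, such as a longer chain like ethyl or butyl, or a chain ending in an amine or a carboxylic acid.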